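Three Limits in Hand, a Fourth Compound Waiting

The compounds below may be only part of what the source reports. "The series", "measured", "known", "first", "only" and "open" are said of these compounds alone.

compound 1 `C/C(=N\NC(=O)c1ccncc1)C(=O)Nc1ccc(F)cc1`: > 50000 nM
compound 2 `C/C(=N\NC(=O)c1ccncc1)C(=O)Nc1ccc(C(F)(F)F)cc1`: > 50000 nM
compound 3 `C/C(=N\NC(=O)c1ccncc1)C(=O)Nc1ccc(OC(F)(F)F)cc1`: > 50000 nM

In an ADME assay on HepG2 cells (Homo sapiens) for cytotoxicity, read by MTT assay (a higher number here means a weaker inhibitor, a lower number a stronger inhibitor), compound 1 gives only a limit, > 50000 nM. Compound 2 likewise gives a limit, > 50000 nM. Compound 3 also gives a limit, > 50000 nM. All three values rest at the limit of > 50000 nM in this assay, at which 3 of the 3 values shown sit, so compound 3 stands level with the other two and no order among them can be read. The steps a step that the two limits leave unreadable from compound 1 to compound 2, a step that the two limits leave unreadable from compound 1 to compound 3 and a step that the two limits leave unreadable from compound 2 to compound 3 are accordingly of unreadable size. Compound 4 `C/C(=N\NC(=O)c1ccncc1)C(=O)Nc1ccc(Cl)cc1` differs from compound 3 by chloro in place of trifluoromethoxy on an aromatic carbon. Among the compounds with values here, no measured step offers a readable size, so for this assay no shift beyond the scatter is expected in either direction. Compound 4 is expected at 60000 nM, between 20000 nM and 200000 nM. The expected step is a step that the limit leaves unreadable from compound 3 to compound 4.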

Compound 4, half-maximal inhibitory concentration: > 50000 nM
Compound 4: a limit, no number; the forecaster's own chance of this, stated with the estimate: 85%; the middle value is on the limit's open side.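

Compound 4, like compound 1, compound 2 and compound 3, gives only a limit, and no step among these four can be read. Where their true values lie, and whether chloro, fluoro, trifluoromethyl and trifluoromethoxy differ at all, stays open.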